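Isopropoxy added to compound 2

The compounds below may be only part of what the source reports. "The series", "measured", "known", "first", "only" and "open" are said of these compounds alone.

- compound 1 `Nc1ncc(C(O)(c2ccc(Cl)cc2)c2cccnc2)s1`: 56000 nM
- compound 2 `OC(c1ccc(Cl)cc1)(c1cccnc1)c1cncnc1`: > 100000 nM (a limit)

In an ADME assay on L6 cells (Rattus norvegicus) for cytotoxicity, read by resazurin assay, with a stated time of 72 h (on this read-out higher numbers stand for weaker inhibition and lower numbers for stronger inhibition), compound 1 gives 56000 nM. Compound 2 stands at the limit of > 100000 nM in this assay, at which 1 of the 2 values shown sits, so its place is a limit and not a number.

Compound 3 `CC(C)Oc1ncc(C(O)(c2ccc(Cl)cc2)c2cccnc2)cn1` takes compound 2 and puts isopropoxy in place of hydrogen on an aromatic carbon.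

Going by the values given here, only one measured step bears on this, an at least 1.7-fold higher number from compound 1 to compound 2 (0.25 log units; that floor lies within the scatter). It swaps a different group, so it is a loose guide, and it stays within the scatter. Among the compounds with values here, compound 1 at 56000 nM is the one reading that shows a number can be obtained for this family. A modest move to a lower number is therefore expected, though another limit reading is quite possible.

The expected change is an at least 1.4-fold lower number from compound 2 to compound 3 (0.15 log units; that floor lies within the scatter). For compound 3 the estimate is 70000 nM, with an expected range from 25000 nM to 150000 nM.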

Compound 3, half-maximal inhibitory concentration: > 100000 nM
Compound 3: no number, only a limit; the forecaster's own chance of this, stated with the estimate: 40%; middle value at least 1.4-fold (0.15 log units) from the limit.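

Compound 2 and compound 3 both give a limit and not a number, so the step between them cannot be read: the limit of > 100000 nM in this assay, at which 2 of the 3 values shown sit.

The compounds shown leave open whether isopropoxy in place of hydrogen on an aromatic carbon changes the reading in this assay at all, and in which direction.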